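The source may report more compounds than this note shows. Statements on the series, on what has been measured and on what is new or still open speak of the compounds shown alone.

Measured so far:
- compound 1 `CCOc1ccccc1-c1ccc(-c2nc3cnccc3cc2C#N)cc1`: 3.8
- compound 2 `CC[C@@H](Nc1c(C#N)c(-c2ccc(Br)cc2)nc2cnccc12)C(=O)O`: 1.6
- compound 3 `CC[C@@H](Nc1c(C#N)c(-c2ccc(-c3cnccc3C)cc2)nc2cnccc12)C(N)=O`: 2

All three values come from a physicochemical assay for lipophilicity, read by HPLC, at pH 7.5; on this read-out lower numbers stand for lower lipophilicity and higher numbers for higher lipophilicity. Compound 3 stands second highest of the three; compound 2 sits beyond the scatter below it, and compound 1 sits furthest away, beyond the scatter above it.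

Compound 4 `CC[C@@H](Nc1c(C#N)c(-c2ccc(-c3ccccc3C(C)C)cc2)nc2cnccc12)C(N)=O` has not yet been measured in this assay. It differs from compound 3 in one place: 2-isopropylphenyl in place of 4-methylpyridin-3-yl on an aromatic carbon. The incoming 2-isopropylphenyl carries no hydrogen-bond acceptor where the departing 4-methylpyridin-3-yl carried one.

For this change a step upward beyond the scatter is expected, a number 1.30 log units higher from compound 3 to compound 4 (beyond the scatter). The estimate for compound 4 in this assay is 3.3, with a range from 2.7 to 3.9.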

Compound 4, distribution coefficient: 3.5
For compound 4 the middle estimate is 0.20 log units below the measured one; the range from low to high includes it.
By their numbers in this assay, from the lowest: compound 2; then compound 3; then compounds 4 and 1 (each within the scatter of the next).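

In this assay, going by these compounds alone, 2-isopropylphenyl in place of 4-methylpyridin-3-yl gives the first single-place step, a number 1.50 log units higher from compound 3 to compound 4 (beyond the scatter), a large one. Within the data shown here, the read-out at this aromatic carbon, para to a large group, therefore responds strongly to this exchange, though this pair is the only evidence for it. Nothing available explains the size of the step.

The step cannot yet be divided between loss of the ring nitrogen and gain of the isopropyl group. Plain phenyl or an isopropyl-bearing pyridine ring would separate the two.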